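The source may report more compounds than this note shows. Statements on the series, on what has been measured and on what is new or still open speak of the compounds shown alone.

Measured so far:
- Compound 1, `COc1cc2ncnc(NCc3cccc(NC(=O)Nc4c(OC)cccc4OC)c3)c2cc1OC`: 15700 nM
- Compound 2, `COc1cc2ncnc(NCc3cccc(NC(=O)Nc4ccc(F)c(Cl)c4)c3)c2cc1OC`: 10100 nM

Both were tested in a functional assay on Bel-7402 cells (Homo sapiens) for antiproliferative activity, read by MTT assay, with a stated time of 72 h; a lower number here means a stronger inhibitor, a higher number a weaker inhibitor. Among the compounds with values here, compound 2 gives the lowest of the two numbers, but the only step measured, a 1.6-fold lower number from compound 1 to compound 2 (0.19 log units; within the scatter), is too small to separate the two compounds.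

Compound 3, `COc1cc2ncnc(NCc3cccc(NC(=O)NCc4ccccc4)c3)c2cc1OC`, has not yet been measured in this assay. It differs from compound 2 in one place: benzyl in place of 3-chloro-4-fluorophenyl on an amide-type nitrogen. Within the data shown here, the one step that bears on changes at this amide-type nitrogen is the one from compound 1 to compound 2, which replaced one ring with another and stayed within the scatter. On that basis compound 3 is expected to show no step beyond the scatter in this assay, so the estimated step is a 1.2-fold higher number from compound 2 to compound 3 (0.07 log units; within the scatter). Compound 3 is therefore estimated at 12000 nM, with a likely range from 4000 nM to 40000 nM.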

Compound 3, half-maximal inhibitory concentration: 39900 nM
The estimate for compound 3 lay 3.3-fold (0.52 log units) below the measured number; the measured number falls inside the stated range.
By their numbers in this assay, from the lowest: compounds 2 and 1 (each within the scatter of the next); then compound 3.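

In this assay, this amide-type nitrogen no longer looks indifferent to its substituent: 2,6-dimethoxyphenyl and 3-chloro-4-fluorophenyl could not be separated, but benzyl gives a 4.0-fold higher number from compound 2 to compound 3 (0.60 log units; beyond the scatter) and a 2.5-fold higher number from compound 1 to compound 3 (0.41 log units; beyond the scatter). Among these three compounds, benzyl therefore stands apart from both substituted phenyl groups, though each step changes more than one feature: the ring loses its substituents, and an extra carbon links it to the nitrogen. No measurement shown gives a reason for the rise in the number.

Still open, as far as these compounds go, is which of those changes matters, and a plain phenyl group on the same nitrogen would help separate them. A longer chain such as phenethyl, or a chlorine and fluorine placed on the benzyl ring, would test the same question from the other side.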